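Methoxy in Place of Fluoro on a Compound at the Limit

The source may hold more compounds than are shown below. What is called first, only, known or untested is meant among the compounds shown, and "the series" means these compounds.

Of the compounds shown here, three sharing one core have been tested in a functional assay on A549 cells (Homo sapiens) for antiproliferative activity, read by MTT assay, with a stated time of 72 h; a lower number here means a stronger inhibitor, a higher number a weaker inhibitor. Compound 1, `COc1cc(-n2ncnc2-c2cccc(F)c2)cc(OC)c1OC`, carries a fluoro group on its outer six-membered ring. In this assay compound 1 gives > 10000 nM, which is a limit of the assay rather than a measured number. Compound 2, `COc1cc(-c2ncnn2-c2cccc([N+](=O)[O-])c2)cc(OC)c1OC`, gives > 10000 nM in this assay, again a limit. Compound 3, `COc1cc(-c2ncnn2-c2ccc([N+](=O)[O-])cc2)cc(OC)c1OC`, gives > 10000 nM in this assay, also a limit. Compound 1 thus stands at the limit of > 10000 nM in this assay, at which 3 of the 3 values shown sit, and no order among the three can be drawn from these results.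

Compound 4, `COc1cccc(-c2ncnn2-c2cc(OC)c(OC)c(OC)c2)c1`, has not yet been measured. It differs from compound 1 in a single place: methoxy in place of fluoro on an aromatic carbon. Among the compounds with values here, no step between two measured compounds is available to show how such a change moves the value, so any expectation rests on where compound 1 itself stands. Since that is a limit, the step expected here is a step that the limit leaves unreadable from compound 1 to compound 4, which is to say none beyond the scatter, with the most likely outcome that compound 4 again reports only a limit. Compound 4 is therefore estimated to give roughly 15000 nM in this assay, within a range from 3000 nM to 60000 nM.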

Compound 4, half-maximal inhibitory concentration: > 10000 nM
Compound 4: only a limit was reported (the forecaster's own chance of this, stated with the estimate: 70%); the middle value lies beyond the limit too.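

Compound 1 and compound 4 both report only a limit in this assay, so no step can be read for methoxy in place of fluoro: the limit of > 10000 nM in this assay, at which 4 of the 4 values shown sit.

With no measured number among them, the compounds shown leave open how any change to the shared core would move the value.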